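A few compounds are considered here, and "the series" means these few. Any claim that something is new, unique, unknown or untested is made for them only; others in the source may bear on it.

The measured compounds in a functional assay on KG-1 cells (Homo sapiens) for cytotoxicity, read by luminescence and CellTiter-Glo, with a stated time of 3 days; on this read-out lower numbers stand for stronger inhibition and higher numbers for weaker inhibition:

Compound 1 `N#Cc1ccc(NC(=O)c2cccc3cc[nH]c23)cc1` gives only a limit, > 10000 nM.
Compound 2 `Cc1ccc(C(=O)Nc2ccc(C#N)cc2)c(O)c1` gives 2560 nM.
Compound 3 `N#Cc1ccc(NC(=O)c2cc(Cc3ccccc3)ccc2O)cc1` gives 1930 nM.

Of the two compounds with a number, compound 3 has the lower one, but its gap to compound 2 lies within the usual scatter, so the two cannot be ranked against each other. The value of compound 1 is a limit of this assay, not a number.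

Compound 4 `N#Cc1ccc(NC(=O)c2cc(Cl)ccc2O)cc1` has not yet been measured. It differs from compound 3 in one place: chloro in place of benzyl on an aromatic carbon. Compounds 2 and 3 carry different groups at comparable positions of the same hydroxy-bearing core yet sit within the scatter of each other, so no step beyond the scatter is expected here. The expected step in this assay is a 1.3-fold higher number from compound 3 to compound 4 (0.11 log units; within the scatter). Compound 4 is estimated at 2500 nM, with a range from 800 nM to 8000 nM.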

Compound 4, half-maximal inhibitory concentration: 1860 nM
The estimate for compound 4 lay 1.3-fold (0.13 log units) above the measured number, within the range that was stated.
By their numbers in this assay, from the lowest: compounds 4, 3 and 2 (each within the scatter of the next). At a limit, above all of these: compound 1.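

At this carbon, para to a hydroxy group, putting chloro in place of benzyl in this assay gives a 1.0-fold lower number from compound 3 to compound 4 (0.02 log units; within the scatter) and so leaves the two compounds indistinguishable. Among the compounds shown here, this is the first pair here that differs in one place, and it shows that a group of 7 heavy atoms with its aromatic ring and a single chlorine atom read alike at this position. Nothing available explains this likeness.

From the compounds shown here alone, whether an amine or a carboxylic acid at this carbon would read differently stays open. So does the part played by the hydroxy group, since no pair shown differs only there.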